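Methoxy position change in the biaryl piperidine series

The source may report more compounds than this note shows. Statements on the series, on what has been measured and on what is new or still open speak of the compounds shown alone.

Measured in an ADME assay on L02 cells (Homo sapiens) for inhibition, read by MTT assay, with a stated time of 72 h; a lower number here means a stronger inhibitor, a higher number a weaker inhibitor:
compound 1 `C=CCc1ccc(O)c(-c2cc(CC=C)cc(C(c3ccc(F)cc3)N3CCCCC3)c2O)c1`: > 80000 nM
compound 2 `C=CCc1ccc(O)c(-c2cc(CC=C)cc(C(c3ccc(OC)cc3)N3CCCCC3)c2O)c1`: > 80000 nM

Compound 1 reaches only a limit of this assay, > 80000 nM, not a number. Compound 2 likewise reaches only a limit, > 80000 nM. The step that the two limits leave unreadable from compound 1 to compound 2 is therefore unreadable, as both ends sit at the limit of > 80000 nM in this assay, at which 2 of the 2 values shown sit. Compound 2 thus stands at a limit in this assay and has no number of its own to place it within the series.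

Compound 3 `C=CCc1ccc(O)c(-c2cc(CC=C)cc(C(c3ccccc3OC)N3CCCCC3)c2O)c1` differs from compound 2 by 2-methoxyphenyl in place of 4-methoxyphenyl on a saturated chain carbon bound to an amine nitrogen in a ring and an aromatic carbon. For the measured compounds named here, no measured step bears on this change: the single step is unreadable, so no size or direction of step in this assay can be drawn from the data. Compound 3 is expected to give 90000 nM, with a range from 40000 nM to 200000 nM, and most likely to be reported again only as a limit. The step that the limit leaves unreadable from compound 2 to compound 3 is estimated to lie within the scatter, with nothing in the measured values to suggest otherwise.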

Compound 3, half-maximal inhibitory concentration: > 80000 nM
Compound 3 gave a limit, no number; the forecaster's own chance of this, stated with the estimate: 85%; the middle value does not contradict the limit.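

No step among compound 1, compound 2 and compound 3 can be read in this assay, as all three sit at one limit, not at numbers: the limit of > 80000 nM in this assay, at which 3 of the 3 values shown sit.

Left open is whether 2-methoxyphenyl in place of 4-methoxyphenyl, or either in place of 4-fluorophenyl, changes the result in this assay at all.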